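Methyl on the Urea Chain in a Dithiocarbamate Series

The source may report more compounds than this note shows. Statements on the series, on what has been measured and on what is new or still open speak of the compounds shown alone.

Compound 1 `CCNC(=O)N1CCN(C(=S)SCc2cn(Cc3ccc(C)cc3)nn2)CC1` and compound 2 `Cc1ccc(Cn2cc(CSC(=S)N3CCN(C(=O)NC(C)C)CC3)nn2)cc1` share one core, while compound 3 `CCNC(=O)N1CCN(C(=S)SCc2cn(Cc3cc(OC)c(OC)c(OC)c3)nn2)CC1` and compound 4 `COc1cc(Cn2cc(CSC(=S)N3CCN(C(=O)NC(C)C)CC3)nn2)cc(OC)c1OC` share another; the difference between the two cores is not broken down here. In a functional assay on MCF7 cells (Homo sapiens) for cytotoxicity, read by MTT assay, with a stated time of 72 h (a lower number here means a stronger inhibitor, a higher number a weaker inhibitor), compound 1 reaches only the limit, > 128000 nM. Compound 2 gives 4630 nM in this assay. This step, an at least 27-fold lower number from compound 1 to compound 2 (1.44 log units; beyond the scatter), goes with methyl in place of hydrogen on a saturated chain carbon bound to an amide-type nitrogen and a saturated chain carbon. Compound 3 likewise stops at the limit in this assay, > 128000 nM, which is the limit of > 128000 nM in this assay, at which 2 of the 3 values shown sit. Compound 4 carries the same change, (methyl in place of hydrogen on a saturated chain carbon bound to an amide-type nitrogen and a saturated chain carbon). Resting on an at least 27-fold lower number from compound 1 to compound 2 (1.44 log units; beyond the scatter) and on the limit at which compound 3 sits, > 128000 nM, the step of an at least 4.2-fold lower number from compound 3 to compound 4 (0.63 log units; beyond the scatter) is expected for compound 4, though with wide uncertainty. Compound 4 is therefore estimated at 30000 nM in this assay, between 3000 nM and 200000 nM.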

Compound 4, half-maximal inhibitory concentration: > 128000 nM
Compound 4 ended at the assay's limit; the forecaster's own chance of this, stated with the estimate: 40%; middle value at least 4.2-fold (0.63 log units) away from the limit.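

For the compounds shown here, compound 3 and compound 4 both end at a limit in this assay and no step between them can be read: the limit of > 128000 nM in this assay, at which 3 of the 4 values shown sit. The compounds shown leave open whether methyl in place of hydrogen at this place lowers the number on the core of compound 3, as it does on the core of compound 1.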